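Half-life in human liver microsomes: a cyclopentylmethyl to oxan-4-yl swap

The compounds below may be only part of what the source reports. "The series", "measured", "known", "first", "only" and "open" are said of these compounds alone.

Two compounds of this series have been run in an in vitro ADME assay on microsomes from liver (Homo sapiens) for metabolic stability, read by LC-MS; a higher number here means that the compound lasts longer, a lower number that the compound disappears faster. Compound 1 `O=C(CCC1CCCC1)N1CCCN(C(=O)Nc2ccccc2)CC1` gives 0.05 h in this assay. Compound 2 `CC(C)(C)c1ccc(NC(=O)N2CCCN(C(=O)CC3CCCC3)CC2)cc1`, which carries a tert-butyl group on the phenyl ring, gives 0.05 h in this assay, level with compound 1 at the digits shown and within the scatter of it. Within the data shown here, no pair of measured compounds differing in one place exists yet, so the effect of any single change on this assay is unknown. Compound 3 `CC(C)(C)c1ccc(NC(=O)N2CCCN(C(=O)C3CCOCC3)CC2)cc1` awaits measurement; it differs from compound 2 by oxan-4-yl in place of cyclopentylmethyl on a carbonyl carbon. Among the measured compounds shown here, with no measured step to lean on, the expectation for compound 3 rests on the value of compound 2, and a step of a 1.6-fold higher number from compound 2 to compound 3 (0.20 log units; within the scatter), small and upward, is expected rather than none beyond the scatter. Compound 3 is estimated at 0.08 h, within a range from 0.04 h to 0.2 h.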

Compound 3, half-life: 0.183 h
For compound 3 the middle estimate is 2.3-fold (0.36 log units) below the measured one, and the stated range covers the measured number.
By their numbers in this assay, from the lowest: compounds 1 and 2 (each within the scatter of the next); then compound 3.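

Among these compounds, compound 2 and compound 3 are the first pair that differ in one place, so a single change can now be read in this assay: oxan-4-yl in place of cyclopentylmethyl on a carbonyl carbon gives a 3.7-fold higher number from compound 2 to compound 3 (0.56 log units; beyond the scatter), a modest step but one that earlier comparisons could not provide. It shows that the number in this assay responds to the group at this position even when the heavy-atom count stays the same. No measurement at hand accounts for the step.

The change alters the ring size, the ring's link to the carbonyl and the presence of oxygen all at once, and the compounds shown do not separate these. Cyclohexyl or piperidin-4-yl on the same carbonyl carbon would help to pull them apart, and whether the step carries over to a phenyl ring without the tert-butyl group also remains open.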